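Spiro-cyclopropyl lactam in place of methyl lactam

The compounds below may be only part of what the source reports. "The series", "measured", "known", "first", "only" and "open" are said of these compounds alone.

Measured so far:
compound 1, `C[C@@H]1CC(=O)N(c2cnc(NCc3c(F)ccc4c3CCO4)n3cnnc23)C1`: < 3 mL.min-1.g-1
compound 2, `Cc1nc(CO)ccc1-c1cnc(NCc2c(F)ccc3c2CCO3)c2cn[nH]c(=O)c12`: 11 mL.min-1.g-1
compound 3, `CN(C)Cc1ccc2c(c1)CN(c1cnc(NCc3c(F)ccc4c3CCO4)n3cnnc13)C2=O`: 19 mL.min-1.g-1

In an ADME assay on microsomes from liver (Homo sapiens) for metabolic stability, read by LC-MS, using NADPH, with stated times of 5 min and 30 min, tested at 1 uM (a higher number here means faster removal of the compound, a lower number slower removal), compound 1 is reported only as a limit, < 3 mL.min-1.g-1, and not as a number. That places compound 1 at the limit of < 3 mL.min-1.g-1 in this assay, at which 1 of the 3 values shown sits, which is the lowest reading of the three shown. In this assay compound 2 gives 11 mL.min-1.g-1 and compound 3 gives 19 mL.min-1.g-1, both of which are numbers rather than limits.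

The next compound, compound 4, `O=C1CC2(CC2)CN1c1cnc(NCc2c(F)ccc3c2CCO3)n2cnnc12`, keeps the shared core of compound 1 and changes one group: a group of 8 heavy atoms (6 carbon, 1 nitrogen, 1 oxygen; one three-membered non-aromatic ring of carbon only, one five-membered non-aromatic ring with 1 hetero atom) in place of a group of 7 heavy atoms (5 carbon, 1 nitrogen, 1 oxygen; one five-membered non-aromatic ring with 1 hetero atom), on an aromatic carbon. For the measured compounds named here, no step between two measured compounds in this set touches that position, so there is no measured reference for the change.

Given that compound 1 sits at the limit in this assay, the expectation for compound 4 is that it also clears slowly, with the step of a number no lower from compound 1 to compound 4 (the limit leaves the size open) within the usual scatter. Compound 4 is therefore estimated at 3 mL.min-1.g-1, with a range from 1 mL.min-1.g-1 to 8 mL.min-1.g-1, and a fair chance that the assay again reports only a limit.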

Compound 4, intrinsic clearance in microsomes: < 3 mL.min-1.g-1
Compound 4 was reported as a limit (the forecaster's own chance of this, stated with the estimate: 55%); the middle value sits exactly at the limit.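

In this assay compound 1 and compound 4 are both reported only as limits, so no step between them can be read: the limit of < 3 mL.min-1.g-1 in this assay, at which 2 of the 4 values shown sit.

The compounds shown leave open whether the spiro-cyclopropyl lactam of compound 4 and the 4-methyl-2-oxopyrrolidin-1-yl group of compound 1 differ in intrinsic clearance at all.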